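Side-chain exchange at the saturated chain carbon, xenograft inhibition

The source may hold more compounds than are shown below. What is called first, only, known or untested is meant among the compounds shown, and "the series" means these compounds.

Measured so far:
Compound 1 `O=C(CC[C@H](NC(=O)c1cc2ccccc2cn1)C(=O)OCc1ccccc1)OCc1ccccc1`: 25.2%
Compound 2 `NC(=O)C[C@H](NC(=O)c1cc2ccccc2cn1)C(=O)OCc1ccccc1`: 36.7%

In a functional assay on the whole organism (CCRF S-180 cells, Mus musculus) for inhibition, in a xenograft, with stated times of 7 days and 24 h, at a dose of 100 umol/kg by the intraperitoneal route (on this read-out higher numbers stand for more inhibition at the one dose given (going by the name of the read-out) and lower numbers for less inhibition), compound 1 gives 25.2% and compound 2 gives 36.7%. Compound 2 stands highest of the two numbers, the nearest being compound 1, with a number 11.5 percentage points higher from compound 1 to compound 2 (beyond the scatter). Compound 3 `CSCC[C@H](NC(=O)c1cc2ccccc2cn1)C(=O)OCc1ccccc1` is not yet measured; it differs from compound 2 by (methylsulfanyl)methyl in place of carbamoyl on a saturated chain carbon, two bonds along the chain from an amide-type nitrogen and a carbonyl carbon. Going by the values given here, the only measured step touches the same position, but no step replaces carbamoyl with a sulfur-bearing group, so the expectation rests on little. A fall back toward compound 1 is expected, a number 8.7 percentage points lower from compound 2 to compound 3 (within the scatter), with wide uncertainty. Compound 3 is estimated at 28%, within 10% to 46%.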

Compound 3, a percentage reported as inhibition, in the whole organism at one dose (the size of the read-out at that dose, not a potency): 39.6%
Beside the measured number, compound 3's estimate is 11.6 percentage points below it; measured number inside the range.
By their numbers in this assay, from the lowest: compound 1; then compounds 2 and 3 (each within the scatter of the next).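

At this position in this assay, the carbamoyl group gives way to (methylsulfanyl)methyl, which has no hydrogen-bond donor, with a number 2.9 percentage points higher from compound 2 to compound 3 (within the scatter), so removing that donor leaves the number within the scatter. Set against the benzyloxycarbonyl-bearing chain, the sulfur-bearing chain gives a number 14.4 percentage points higher from compound 1 to compound 3 (beyond the scatter), so compound 1 now sits apart from two side chains that differ in donor count. Nothing measured here accounts for these numbers.

Going by these compounds, how an amine or a carboxylic acid at the end of this side chain would read remains open. On these data alone, a longer chain ending in methylsulfanyl also remains open.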